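The source may report more compounds than this note shows. Statements on the series, on what has been measured and on what is new or still open speak of the compounds shown alone.

Measured so far in a functional assay (trachea) with Cavia porcellus as the target; on this read-out higher numbers stand for weaker inhibition and lower numbers for stronger inhibition:
- compound 1 `Cn1nc(-c2cccnc2)c2ccccc2c1=O`: 11500 nM
- compound 2 `CC(C)=CCn1nc(-c2cccnc2)c2ccccc2c1=O`: 1380 nM
- compound 3 `O=c1c2ccccc2c(-c2cccnc2)nn1Cc1ccccc1`: 2450 nM

Compound 3 cannot be told apart from compound 2, with a 1.8-fold higher number from compound 2 to compound 3 (0.25 log units; within the scatter). Compared with the hydrogen case, the picture is a 4.7-fold lower number from compound 1 to compound 3 (0.67 log units; beyond the scatter).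

Next is compound 4 `CCOC(=O)Cn1nc(-c2cccnc2)c2ccccc2c1=O`, with ethoxycarbonyl in place of phenyl on a saturated chain carbon bound to an aromatic nitrogen. Within the data shown here, no measured compound carries this group, so the evidence is indirect. The relevant steps at the same place are an 8.3-fold lower number from compound 1 to compound 2 (0.92 log units; beyond the scatter) and a 4.7-fold lower number from compound 1 to compound 3 (0.67 log units; beyond the scatter). Exchanging the two larger groups gave only a 1.8-fold higher number from compound 2 to compound 3 (0.25 log units; within the scatter). In these three compounds, both groups gave lower numbers than hydrogen and did not separate from each other. The data do not show what the incoming acceptors do, so the range stays wide, reaching towards compound 1.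

No shift beyond the scatter is expected, and the estimated step is a 1.3-fold higher number from compound 3 to compound 4 (0.12 log units; within the scatter). Compound 4 is estimated at 3200 nM, with an expected range of 1100 nM to 9500 nM.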

Compound 4, half-maximal inhibitory concentration: 43700 nM
Beside the measured number, compound 4's estimate is 14-fold (1.14 log units) below it; the measured number lies above the stated range.
By their numbers in this assay, from the lowest: compounds 2 and 3 (each within the scatter of the next); then compound 1; then compound 4.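

In this assay, substitution at this place does not always give lower numbers. Ethoxycarbonyl in place of phenyl gives a large rise (an 18-fold higher number from compound 3 to compound 4 (1.25 log units; beyond the scatter)), and ethoxycarbonyl in place of 2-methylprop-1-en-1-yl gives a larger one on paper (a 32-fold higher number from compound 2 to compound 4 (1.50 log units; beyond the scatter)), while even the hydrogen case stays lower (a 3.8-fold higher number from compound 1 to compound 4 (0.58 log units; beyond the scatter)). The gain seen with compound 2 and compound 3 therefore does not extend to compound 4, and nothing available accounts for this reversal.

Going by these compounds, it remains open whether the higher number follows the whole ethoxycarbonyl group or only part of it, which a carboxylic acid, a primary amide or a simple ketone at this place could help to separate. On these data alone, it is also open how a longer chain between the aromatic nitrogen and the ester would read.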